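From methoxy to fluoro on compound 3

The compounds below may be only part of what the source reports. "The series", "measured", "known", "first", "only" and "open" are said of these compounds alone.

In an ADME assay on microsomes from liver (Homo sapiens) for metabolic stability (on this read-out higher numbers stand for fast clearance and lower numbers for slow clearance), compound 3 `COc1ccc2nnn(CC(=O)N[C@@H](C)c3ccc(C)cc3)c(=O)c2c1` gives 58 mL/min/kg, within the usual scatter of compound 2 `COc1cc(C)ccc1[C@H](C)NC(=O)Cn1nnc2ccccc2c1=O` at 30 mL/min/kg. Compound 1 `Cc1ccc([C@H](C)NC(=O)Cn2nnc3ccccc3c2=O)cn1` is reported only as a limit, < 9.9 mL/min/kg. Compound 4 `Cc1ccc([C@H](C)NC(=O)Cn2nnc3ccc(F)cc3c2=O)cc1` differs from compound 3 by having fluoro in place of methoxy on an aromatic carbon. Going by the values given here, no measured pair shows this exchange or isolates any other single change, so the three values give no direct guide to its size. No shift beyond the scatter is therefore expected in this assay, and the estimated change is a small one, a 1.5-fold lower number from compound 3 to compound 4 (0.16 log units; within the scatter). For compound 4 the estimated clearance is 40 mL/min/kg, with an expected range of 18 mL/min/kg to 85 mL/min/kg.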

Compound 4, clearance: 182 mL/min/kg
Compound 4: the middle estimate sits 4.6-fold (0.66 log units) below what was measured, and the stated range ends below it.
By their numbers in this assay, from the lowest: compounds 2 and 3 (each within the scatter of the next); then compound 4. At a limit, below all of these: compound 1.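

Going by these compounds alone, with fluoro in place of methoxy on this aromatic carbon, meta to a fused ring and para to a fused ring, this assay shows a 3.1-fold higher number from compound 3 to compound 4 (0.50 log units; beyond the scatter) and so gives the first single change that can be read. The substituent at this position therefore moves the clearance beyond the scatter, and the exchange takes it upward. Nothing shown here accounts for the size or direction of this step. Still open, from the compounds shown here alone, is whether the step follows from fluoro entering or methoxy leaving, and how an amine or a nitrile on this carbon would compare.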